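Repositioning Two Fluorines on the Pendant Ring

This account rests on a few compounds, and the source may have more. Where it says the series, first, only, none or still open, it means among the compounds named here.

Compound 3 `O=C(Nc1ccc(F)c(-c2nc3ncc(-c4cc(F)ccc4F)cc3[nH]2)c1)N1CCCC1` was tested in an ADME assay on HepG2 cells (Homo sapiens) for cytotoxicity, read by resazurin assay, with a stated time of 48 h (on this read-out higher numbers stand for an effect only at larger amounts of compound and lower numbers for an effect already at smaller amounts), where compound 3 gives only a limit of the assay, > 50000 nM, and not a number. Compound 1 `Cc1nc(C)c(C(=O)Nc2ccc(F)c(-c3nc4ncc(-c5cccnc5Cl)cn4n3)c2)o1` likewise gives only a limit in this assay, > 50000 nM. Compound 2 `O=C(Nc1ccc(F)c(-c2nc3ncc(-c4cccc(F)c4)cc3[nH]2)c1)N1CCCC1` gives 28200 nM in this assay. For the measured compounds named here, the single step between measured compounds is an at least 1.7-fold higher number from compound 2 to compound 3 (0.24 log units; that floor lies within the scatter), whose floor is set by the limit of > 50000 nM in this assay, at which 2 of the 3 values shown sit. Compound 4 `O=C(Nc1ccc(F)c(-c2nc3ncc(-c4cc(F)cc(F)c4)cc3[nH]2)c1)N1CCCC1` differs from compound 3 by 3,5-difluorophenyl in place of 2,5-difluorophenyl on an aromatic carbon. Going by the values given here, no measured step moves fluorines around this ring, so no direction is indicated; the change is expected to stay within the scatter, a number no higher from compound 3 to compound 4 (the limit leaves the size open). Compound 4 is therefore estimated at 50000 nM, in the range 25000 nM to 100000 nM, and most probably again reported as a limit.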

Compound 4, half-maximal effective concentration: > 50000 nM
Compound 4 was reported as a limit (the forecaster's own chance of this, stated with the estimate: 70%); the middle value sits exactly at the limit.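

In this assay, compound 4 gives > 50000 nM, a limit of the assay and not a number. Fluoro in place of hydrogen on the pendant ring now appears in a second arrangement, with an at least 1.7-fold higher number from compound 2 to compound 4 (0.24 log units; that floor lies within the scatter). The two limits leave the step from compound 3 to compound 4 unreadable, so the two difluorophenyl arrangements cannot be told apart here: the limit of > 50000 nM in this assay, at which 3 of the 4 values shown sit.

From the compounds shown here alone, whether an amine or a carboxylic acid on the pendant ring would bring a readable number remains open. So does whether a methoxy group in place of fluoro would do so.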